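The source may hold more compounds than are shown below. What is called first, only, known or untested is meant among the compounds shown, and "the series" means these compounds.

Series read in a functional assay on SEM cells (Homo sapiens) for inhibition, read by MTT assay, with a stated time of 72 h; on this read-out higher numbers stand for weaker inhibition and lower numbers for stronger inhibition:

- compound 1 `C=C(Br)C(=O)Nc1cccc(/C=C/C(=O)Nc2ccccc2)c1`: 1100 nM
- compound 2 `C=C(Br)C(=O)Nc1cccc(/C=C/C(=O)Nc2ccc(F)cc2)c1`: 8400 nM
- compound 3 `C=C(Br)C(=O)Nc1cccc(/C=C/C(=O)Nc2ccc(C)cc2)c1`: 190 nM

Compound 3 gives the lowest of the three numbers, and its steps to both other compounds lie beyond the scatter. The next structure is compound 4 `C=C(Br)C(=O)Nc1cccc(/C=C/C(=O)NCc2ccc(C)cc2)c1`, which has 4-methylbenzyl in place of 4-methylphenyl on an amide-type nitrogen. The 4-methyl group stays, but the ring is now attached to the nitrogen through the benzyl group.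

Going by the values given here, no measured step makes this kind of change, so the evidence is indirect. The nearest evidence comes from substitutions on the aromatic ring: a 5.8-fold lower number from compound 1 to compound 3 (0.76 log units; beyond the scatter) and a 7.6-fold higher number from compound 1 to compound 2 (0.88 log units; beyond the scatter), both modest, and a 44-fold lower number from compound 2 to compound 3 (1.65 log units; beyond the scatter), which is large. These steps show that the numbers in this assay can move well beyond the scatter with a single change at this end of the molecule. Starting from the lowest number in the series, with 190 nM for compound 3, a modest move towards a higher number is expected, though the direction is not established. The estimated change is a 4.7-fold higher number from compound 3 to compound 4 (0.68 log units; beyond the scatter). For compound 4 the expected value is 900 nM, with an estimated range from 200 nM to 4500 nM.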

Compound 4, half-maximal inhibitory concentration: 1300 nM
Compound 4: the middle estimate sits 1.4-fold (0.16 log units) below what was measured, and the stated range covers the measured number.
By their numbers in this assay, from the lowest: compound 3; then compounds 1 and 4 (each within the scatter of the next); then compound 2.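

In this assay, moving from the aryl to the benzyl attachment on the amide-type nitrogen gives a 6.8-fold higher number from compound 3 to compound 4 (0.84 log units; beyond the scatter), so this position responds to a change in how the ring is attached, and not only to substitution on the ring. The low number of compound 3 therefore depends on more than the 4-methyl group, which is present in both compounds; compared with the unsubstituted phenyl, 4-methylbenzyl gives a 1.2-fold higher number from compound 1 to compound 4 (0.07 log units; within the scatter), which places the pair within the scatter. Compared with 4-fluorophenyl, the same group gives a 6.5-fold lower number from compound 2 to compound 4 (0.81 log units; beyond the scatter), and no measurement shown offers an explanation for any of these steps.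

The compounds shown leave open how unsubstituted benzyl or 4-fluorobenzyl would read on this nitrogen, so the contribution of the 4-methyl group within the benzyl form cannot be separated from that of the added carbon. Also open, on these data alone, is whether a longer chain, such as 2-phenylethyl, would continue the move seen from compound 3 to compound 4, and how an amine or a carboxylic acid on the ring would read at this end of the molecule.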